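Chloro to nitro: what one small step suggests

The source may report more compounds than this note shows. Statements on the series, on what has been measured and on what is new or still open speak of the compounds shown alone.

Of the compounds shown here, two sharing one core have been measured in a functional assay on Caco-2 cells (Homo sapiens) for cytotoxicity, with a stated time of 48 h; on this read-out lower numbers stand for stronger inhibition and higher numbers for weaker inhibition. Compound 1 `COc1cc(OC)c(C(=O)/C=C/c2ccccc2OC)c(OC)c1` gives 4500 nM, and compound 2 `COc1cc(OC)c(C(=O)/C=C/c2ccc(Cl)cc2)c(OC)c1` gives 5700 nM. These two numbers lie within the usual scatter of each other, so compound 2 stands level with compound 1 and the two cannot be ranked. The next compound, compound 3 `COc1cc(OC)c(C(=O)/C=C/c2ccc([N+](=O)[O-])cc2)c(OC)c1`, keeps the core and carries nitro in place of chloro on an aromatic carbon, para to a large group: nitro in place of chloro on an aromatic carbon. Going by the values given here, only one measured step offers any guidance, a 1.3-fold higher number from compound 1 to compound 2 (0.10 log units; within the scatter), with 4-chlorophenyl in place of 2-methoxyphenyl. Among the compounds with values here, that step stayed within the scatter, but it is a different swap, and no compound with a nitro group has been measured yet. Within the data shown here, with so small a step as the only guide, no step beyond the scatter is expected in this assay. The estimated step is a 1.1-fold lower number from compound 2 to compound 3 (0.06 log units; within the scatter), and it is a cautious forecast. Compound 3 is estimated at 5000 nM, with an expected range from 2000 nM to 12000 nM.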

Compound 3, half-maximal inhibitory concentration: 2600 nM
For compound 3 the middle estimate is 1.9-fold (0.28 log units) above the measured one; the range from low to high includes it.
By their numbers in this assay, from the lowest: compounds 3, 1 and 2 (each within the scatter of the next, the first and the last beyond it).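

Going by these compounds alone, exchanging chloro for nitro on this aromatic carbon, para to a large group, gives the first step in this assay that clears the usual scatter: a 2.2-fold lower number from compound 2 to compound 3 (0.34 log units; beyond the scatter). The step is modest, but it shows that the number can respond to a single group exchanged at this one position, which the earlier pair could not show, since its step changed both the group and where it sits on the ring and stayed within the scatter. Nitro brings three heavy atoms and two hydrogen-bond acceptors where chloro brought one heavy atom and none, yet nothing available here indicates which of these differences, if any, lies behind the step.

One pair cannot say whether this step is particular to nitro or whether another group at the same position, such as an amine, a nitrile or a carboxylic acid, would shift the number as far or further. From the compounds shown here alone, it also remains open whether nitro would give a similar step on another carbon of this ring.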